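Pyrimidinyl for pyridinyl on a vinyl sulfone core

A few compounds are considered here, and "the series" means these few. Any claim that something is new, unique, unknown or untested is made for them only; others in the source may bear on it.

Compound 1 `COc1ccccc1S(=O)(=O)/C=C/c1ccncc1`: 1520 nM
Compound 2 `COc1cccc(S(=O)(=O)/C=C/c2ccncc2)c1`: 655 nM
Compound 3 `COc1ccccc1S(=O)(=O)/C=C/c1cncnc1`: > 10000 nM

In an assay on U2OS cells for activation of nuclear factor erythroid 2-related factor 2 (Homo sapiens), read by chemiluminescence, with a stated time of 6 h (on this read-out higher numbers stand for an effect only at larger amounts of compound and lower numbers for an effect already at smaller amounts), compound 1 gives 1520 nM and compound 2 gives 655 nM. The difference between the two cores of compound 1 and compound 2 is not broken down here. For compound 3 the value > 10000 nM is a limit of the assay and not a number. The change from compound 1 to compound 3 is pyrimidin-5-yl in place of pyridin-4-yl on a double-bonded chain carbon bound to a double-bonded chain carbon and it made a step of an at least 6.5-fold higher number from compound 1 to compound 3 (0.81 log units; beyond the scatter); the size is known only as a lower bound because the limit of > 10000 nM in this assay, at which 1 of the 3 values shown sits, caps what can be read.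

Compound 4 `COc1cccc(S(=O)(=O)/C=C/c2cncnc2)c1` has not yet been measured. It differs from compound 2 by pyrimidin-5-yl in place of pyridin-4-yl on a double-bonded chain carbon bound to a double-bonded chain carbon, the same change at the same place as before. The step from compound 2 to compound 4 is expected to be a 9.2-fold higher number from compound 2 to compound 4 (0.96 log units; beyond the scatter), resting on the earlier step of an at least 6.5-fold higher number from compound 1 to compound 3 (0.81 log units; beyond the scatter). Compound 4 is therefore estimated at 6000 nM, between 2500 nM and 20000 nM, with a real chance that only a limit is reported.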

Compound 4, half-maximal effective concentration: 7380 nM
Compound 4: middle estimate off by 1.2-fold (0.09 log units), on the low side, within the range that was stated.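

In this assay, pyrimidin-5-yl in place of pyridin-4-yl gave an 11-fold higher number from compound 2 to compound 4 (1.05 log units; beyond the scatter), so the change moved the number in the same direction on both cores: the same change on two cores in this assay, an at least 6.5-fold higher number (0.81 log units; beyond the scatter) from compound 1 to compound 3 and an 11-fold higher number (1.05 log units; beyond the scatter) from compound 2 to compound 4; the limit leaves it open whether they differ For compound 3, the value > 10000 nM is a limit of the assay and not a number: the limit of > 10000 nM in this assay, at which 1 of the 4 values shown sits. The direction therefore carried over from the core of compound 1 to the core of compound 2, but two cores do not establish a general rule, nor do they show that the size of the step carries over.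

The compounds shown leave open how a phenyl ring in place of pyridin-4-yl would read. They also leave open whether the same change would hold on a core carrying an amine or a chlorine instead of the methoxy group.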